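Tetrazole for Methoxy: Solubility Outlook for Compound 3

The compounds below may be only part of what the source reports. "The series", "measured", "known", "first", "only" and "open" are said of these compounds alone.

Measured so far:
compound 1 `COc1ccc(Nc2cc3[nH]c(-c4cccc(C(F)(F)F)c4)nc3cn2)nc1`: < 5000 nM
compound 2 `FC(F)(F)c1cccc(-c2nc3cnc(Nc4cnccn4)cc3[nH]2)c1`: < 5000 nM

In a physicochemical assay for solubility, using the shake flask method, in phosphate buffer, measured as kinetic solubility, with a stated time of 20 h, at pH 6.5 (a higher number here means a more soluble compound, a lower number a less soluble compound), compound 1 gives < 5000 nM; this value is a limit of the assay, not a number. Compound 2 gives < 5000 nM, likewise a limit. The step that the two limits leave unreadable from compound 1 to compound 2 therefore cannot be read, and the limit of < 5000 nM in this assay, at which 2 of the 2 values shown sit, covers everything measured. Compound 3 `FC(F)(F)c1cccc(-c2nc3cnc(Nc4ccc(-c5nnn[nH]5)cn4)cc3[nH]2)c1` differs from compound 1 by 1H-tetrazol-5-yl in place of methoxy on an aromatic carbon. Within the data shown here, no measured step bears on this change, so no direction can be drawn from the data. Compound 3 is expected to give 3000 nM in this assay, with a range of 500 nM to 20000 nM. The expected step that the limit leaves unreadable from compound 1 to compound 3 is estimated to stay within the scatter, and a limit rather than a number is likely.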

Compound 3, solubility: < 5000 nM
Compound 3: a limit, no number; the forecaster's own chance of this, stated with the estimate: 60%; the middle value is on the limit's open side.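

Among these compounds, compound 3 gives < 5000 nM, a limit and not a number, so no step from compound 1 to compound 3 can be read. The actual solubility of each compound and any order among them stay open, as all three share one limit: the limit of < 5000 nM in this assay, at which 3 of the 3 values shown sit.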